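Adding a Second Fluoro to a Sulfonamide Series

This account rests on a few compounds, and the source may have more. Where it says the series, first, only, none or still open, it means among the compounds named here.

Three compounds have been measured:

Compound 1, `CCOC(=O)C1=CCCCC1S(=O)(=O)Nc1cccc(F)c1`, gives 150 nM in a functional assay on RAW264.7 cells (Mus musculus) for inhibition; a lower number here means a stronger inhibitor, a higher number a weaker inhibitor.
Compound 2, `CCOC(=O)C1=CCCCC1S(=O)(=O)Nc1ccc(F)cc1`, gives 110 nM in this assay.
Compound 3, `CCOC(=O)C1=CCCCC1S(=O)(=O)Nc1cccc(F)c1F`, gives 140 nM in this assay.

Compounds 1 and 2 share the same atoms joined differently: 4-fluorophenyl in place of 3-fluorophenyl on a sulfonamide nitrogen. That rearrangement gave a 1.4-fold lower number from compound 1 to compound 2 (0.13 log units; within the scatter), so the two values cannot be told apart. From compound 1 to compound 3 a single atom is added, (fluoro in place of hydrogen on an aromatic carbon), and the result was a 1.1-fold lower number from compound 1 to compound 3 (0.03 log units; within the scatter), again a change too small to count.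

Compound 4, `CCOC(=O)C1=CCCCC1S(=O)(=O)Nc1ccc(F)cc1F`, has not yet been measured. It stands to compound 2 as compound 3 stands to compound 1: fluoro in place of hydrogen on an aromatic carbon. The two changes are the same kind of change, but not the same. In compound 3 the new fluoro sits ortho to a fluoro group and ortho to a large group, whereas in compound 4 it sits ortho to a large group and meta to a fluoro group. Among the measured compounds shown here, the only guide is the earlier step, which was flat, and the fact that compound 2 itself sits in the same narrow band as compounds 1 and 3.

The step from compound 2 to compound 4 is therefore expected to be about a 1.1-fold lower number from compound 2 to compound 4 (0.04 log units; within the scatter), resting on the earlier 1.1-fold lower number from compound 1 to compound 3 (0.03 log units; within the scatter). For compound 4 a value near 100 nM is estimated, most likely between 50 nM and 220 nM in this assay.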

Compound 4, half-maximal inhibitory concentration: 16 nM
Compound 4: middle estimate off by 6.3-fold (0.80 log units), on the high side, and the stated range ends above it.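

In this assay the added fluoro gave a 6.9-fold lower number from compound 2 to compound 4 (0.84 log units; beyond the scatter) and this step is larger than the usual scatter, whereas the same kind of change left the core of compound 1 with no readable shift. So the result of adding this fluoro on one core did not carry over in size to the other, even though the two cores differ only in where their first fluoro sits: the same change on two cores in this assay, a 1.1-fold lower number (0.03 log units; within the scatter) from compound 1 to compound 3 and a 6.9-fold lower number (0.84 log units; beyond the scatter) from compound 2 to compound 4, 6.4-fold (0.81 log units) apart, beyond the scatter of two such steps

This shows that the effect of the change depends on the core it is made on, but these two pairs give no reason for the gap, and they cannot say whether a further core would follow the large step or the flat one. Nor do they set a general rule for fluoro groups in this series.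

Still open, going by these compounds, is whether the gain in compound 4 belongs to fluoro itself, or whether a chloro, methyl or nitrile group ortho to a large group and meta to a fluoro group would give a similar step. On these data alone, it is also open whether the gain survives when the ethyl ester of compound 4 gives way to a carboxylic acid or an amide.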